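The source may report more compounds than this note shows. Statements on the series, on what has been measured and on what is new or still open speak of the compounds shown alone.

Compound 1 `Cc1nc2c3ccccc3ccc2c2nc3c(ccc4ccccc43)c(-c3cccc4ccccc34)c12`; in a functional assay on HeLa cells (Homo sapiens) for cytotoxicity, read by MTT assay, with a stated time of 48 h (on this read-out higher numbers stand for weaker inhibition and lower numbers for stronger inhibition), compound 1 gives 14900 nM.
Compound 2 `Cc1nc2c3ccccc3ccc2c2nc3c(ccc4ccccc43)c(-c3cc([N+](=O)[O-])ccc3N)c12`; compound 2 gives 5770 nM.
Compound 3 `Cc1nc2c3ccccc3ccc2c2nc3c(ccc4ccccc43)c(-c3ccccc3Cl)c12`; compound 3 gives > 80000 nM, which is a limit of the assay and not a number.

Compound 3 therefore stands at the weak end of the three: the limit of > 80000 nM in this assay, at which 1 of the 3 values shown sits, so its true value is not known, only that it lies beyond that limit. Compound 4 `Cc1nc2c3ccccc3ccc2c2nc3c(ccc4ccccc43)c(-c3ccc(O)cc3)c12` differs from compound 3 in one place: 4-hydroxyphenyl in place of 2-chlorophenyl on an aromatic carbon.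

For the measured compounds named here, two measured steps bear on this position. The change from naphthalen-1-yl to 2-chlorophenyl gave an at least 5.3-fold higher number from compound 1 to compound 3 (0.72 log units; beyond the scatter), and the change from 2-amino-5-nitrophenyl to 2-chlorophenyl gave an at least 13-fold higher number from compound 2 to compound 3 (1.14 log units; beyond the scatter). Both show that the 2-chlorophenyl group of compound 3 sits at the weakest end of what has been seen, so replacing it is expected to lower the number, most likely by a modest to large amount, though with compound 3 known only as a limit the size of that step is uncertain.

Compound 4 is therefore estimated at 15000 nM, with a range from 4000 nM to 80000 nM. That estimate means an expected step of an at least 5.3-fold lower number from compound 3 to compound 4 (0.72 log units; beyond the scatter).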

Compound 4, half-maximal inhibitory concentration: 4630 nM
Beside the measured number, compound 4's estimate is 3.2-fold (0.51 log units) above it, and the stated range covers the measured number.
By their numbers in this assay, from the lowest: compounds 4 and 2 (each within the scatter of the next); then compound 1. At a limit, above all of these: compound 3.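

The position tolerates a single six-membered ring well: 4-hydroxyphenyl in place of 2-chlorophenyl gives an at least 17-fold lower number from compound 3 to compound 4 (1.23 log units; beyond the scatter), a step that is only a bound, because compound 3 stands at a limit: the limit of > 80000 nM in this assay, at which 1 of the 4 values shown sits.

The two groups carry the same count of heavy atoms, so that count alone does not set the number in this assay. The 4-hydroxyphenyl group also matches the larger 2-amino-5-nitrophenyl group, with a 1.2-fold lower number from compound 2 to compound 4 (0.10 log units; within the scatter), and it improves on naphthalen-1-yl, with a 3.2-fold lower number from compound 1 to compound 4 (0.51 log units; beyond the scatter).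

As far as these compounds go, what stays open is whether the hydroxyl group itself matters or whether removing the chlorine is enough. An unsubstituted phenyl, a 4-methoxyphenyl or a 4-aminophenyl group at this carbon would separate those two readings.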